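Amide variation at the shared core, cytotoxicity on HeLa cells

The source may hold more compounds than are shown below. What is called first, only, known or untested is meant among the compounds shown, and "the series" means these compounds.

Measured so far, in a functional assay on HeLa cells (Homo sapiens) for cytotoxicity, read by MTT assay, with a stated time of 24 h; a lower number here means a stronger inhibitor, a higher number a weaker inhibitor:
Compound 1 `C=CC1=C(C(=O)NCCC)C(c2ccc(F)cc2)OC1`: compound 1 gives > 100000 nM, a limit of the assay.
Compound 2 `C=CC1=C(C(=O)NCc2ccc(C)cc2)C(c2ccc(F)cc2)OC1`: compound 2 gives > 100000 nM, a limit of the assay.
Compound 3 `C=CC1=C(C(=O)Nc2ccccc2)C(c2ccc(F)cc2)OC1`: compound 3 gives > 100000 nM, a limit of the assay.

Compound 2 therefore stands on a limit and not on a number; all three values shown sit at the same limit, as summarised in the limit of > 100000 nM in this assay, at which 3 of the 3 values shown sit. The steps between the measured compounds, a step that the two limits leave unreadable from compound 1 to compound 2, a step that the two limits leave unreadable from compound 1 to compound 3 and a step that the two limits leave unreadable from compound 2 to compound 3, remain unreadable, since both ends of each lie at a limit. Changing the group on the amide-type nitrogen from propyl through 4-methylbenzyl to phenyl thus brought no measurable cytotoxicity into the series.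

Compound 4 `C=CC1=C(C(=O)NCc2ccc(C)cc2)C(c2ccc(OC)cc2)OC1` keeps the 4-methylbenzyl amide of compound 2 and differs only in the substituent on the other aromatic ring: methoxy in place of fluoro on an aromatic carbon. Among the compounds with values here, none of the measured steps touches this ring, so no step bears directly on the change. With compound 2 at a limit, the step that the limit leaves unreadable from compound 2 to compound 4 is expected to be unreadable as well, and compound 4 is expected to give 150000 nM, between 50000 nM and 500000 nM, most likely reported again as a limit.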

Compound 4, half-maximal inhibitory concentration: 15900 nM
The estimate for compound 4 lay 9.4-fold (0.97 log units) above the measured number; measured number outside the range, below it.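

In this assay, methoxy in place of fluoro on an aromatic carbon, para to a large group, gives an at least 6.2-fold lower number from compound 2 to compound 4 (0.79 log units; beyond the scatter). This shows that the 4-fluorophenyl position responds to substitution, whereas the amide changes among compounds 1, 2 and 3 gave only steps that cannot be read. The 4-methoxyphenyl change in compound 4 is therefore the one change shown that brings a value inside the range of the assay, with the other three compounds remaining at its limit: the limit of > 100000 nM in this assay, at which 3 of the 4 values shown sit.

On these data alone, compound 2 stands on a limit, so the full size of the step remains open, as does whether 4-methoxyphenyl lowers the number to a similar extent with the propyl or phenyl amide in place of the 4-methylbenzyl amide. The compounds shown also leave open whether the oxygen or the added carbon of methoxy matters more, a question that a hydroxy or methyl group at the same place on the ring would address, and whether an ethoxy group would take the number lower still.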